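The compounds below may be only part of what the source reports. "The series", "measured", "known", "first", "only" and "open" are said of these compounds alone.

Series notes. Compound 2 `Cc1ccccc1Oc1ccc(N2CCC[C@H]2CC(=O)O)cc1` and compound 1 `Cc1ccccc1Oc1ccc(N2C[C@@H](C(F)(F)F)C[C@H]2CC(=O)O)cc1` share one core; compound 3 `COc1ccc(F)c(-c2ccc(Cc3ccc(N4CCC[C@H]4CC(=O)O)cc3)c(C)c2)c1` and compound 4 `COc1ccc(F)c(-c2ccc(Cc3ccc(N4C[C@@H](C(F)(F)F)C[C@H]4CC(=O)O)cc3)c(C)c2)c1` share another. The difference between the two cores is not broken down here. In a functional assay on cells for agonist activity at Free fatty acid receptor 1 (Homo sapiens), read by FLIPR and calcium flux, with a stated time of 100 s (a higher number here means that more compound is needed for the effect, a lower number that less compound is needed), compound 2 gives 74 nM and compound 1 gives 73 nM; the change between them is trifluoromethyl in place of hydrogen on a saturated ring carbon and the step is a 1.0-fold lower number from compound 2 to compound 1 (0.01 log units; within the scatter). In this assay compound 3 gives 220 nM, the highest number of the three measured. Compound 4 carries the same change on the core of compound 3: trifluoromethyl in place of hydrogen on a saturated ring carbon; the surroundings of the place are described in the same words for both pairs. Because the step of a 1.0-fold lower number from compound 2 to compound 1 (0.01 log units; within the scatter) stays within the scatter, a step of about the same size is expected here, a 1.0-fold lower number from compound 3 to compound 4 (0.02 log units; within the scatter). Compound 4 is therefore expected to give 210 nM, within 90 nM to 480 nM.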

Compound 4, half-maximal effective concentration: 490 nM
The estimate for compound 4 lay 2.3-fold (0.37 log units) below the measured number; the measured number lies above the stated range.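

In this assay, trifluoromethyl in place of hydrogen on a saturated ring carbon gives a 2.2-fold higher number from compound 3 to compound 4 (0.35 log units; beyond the scatter), and on the other core it gives a 1.0-fold lower number from compound 2 to compound 1 (0.01 log units; within the scatter). Set side by side, the two steps cannot be told apart: the same change on two cores in this assay, a 1.0-fold lower number (0.01 log units; within the scatter) from compound 2 to compound 1 and a 2.2-fold higher number (0.35 log units; beyond the scatter) from compound 3 to compound 4, 2.3-fold (0.35 log units) apart, within the scatter of two such steps. For the compounds shown here, this does not show that the change carries over unaltered from one core to the other, as the series offers only two pairs, with one step within the scatter and the other beyond it, but it gives no evidence of a real dependence on the core either.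

From the compounds shown here alone, it remains open whether a smaller group on the same saturated ring carbon, such as a methyl or a hydroxyl group, would give similar steps on both cores.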